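The compounds below may be only part of what the source reports. "The series", "measured", "known", "first", "only" and "open" are said of these compounds alone.

Compound 2 `COc1ccc(CCCN2CCC[C@H]2COC(c2ccccc2)c2ccc(Cl)cc2)cc1` carries a 2-(4-methoxyphenyl)ethyl group on a saturated chain carbon bound to an amine nitrogen in a ring. Within the data shown here, in a functional assay on LNCaP cells (Homo sapiens) for inhibition (on this read-out lower numbers stand for stronger inhibition and higher numbers for weaker inhibition), compound 2 gives 3500 nM, the lowest of the two numbers measured so far. Its nearest neighbour is compound 1 `COc1ccc(CN2CCC[C@H]2COC(c2ccccc2)c2ccc(Cl)cc2)cc1`, which in this assay gives 7700 nM; the step of a 2.2-fold lower number from compound 1 to compound 2 (0.34 log units; beyond the scatter) is modest but lies beyond the scatter. Compound 3 `CN1CCC[C@H]1COC(c1ccccc1)c1ccc(Cl)cc1` has not been measured. It differs from compound 2 in one place: hydrogen in place of 2-(4-methoxyphenyl)ethyl on a saturated chain carbon bound to an amine nitrogen in a ring. Among the measured compounds shown here, only the step from compound 1 to compound 2 bears on this change, and it speaks to lengthening the chain that carries the aromatic ring rather than to removing the whole group; it gives no direct guide to what happens when the aromatic ring leaves altogether. Given the small change seen across a 2.2-fold lower number from compound 1 to compound 2 (0.34 log units; beyond the scatter), the expectation for compound 3 is that its number in this assay moves upward by the step of a 3.4-fold higher number from compound 2 to compound 3 (0.54 log units; beyond the scatter), with wide uncertainty. The estimate for compound 3 in this assay is 12000 nM, expected between 3000 nM and 50000 nM.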

Compound 3, half-maximal inhibitory concentration: 17000 nM
For compound 3 the middle estimate is 1.4-fold (0.15 log units) below the measured one; measured number inside the range.
By their numbers in this assay, from the lowest: compound 2; then compound 1; then compound 3.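

Removing the whole group costs more than shortening it: hydrogen in place of 2-(4-methoxyphenyl)ethyl gives a 4.9-fold higher number from compound 2 to compound 3 (0.69 log units; beyond the scatter), while hydrogen in place of 4-methoxyphenyl gives a 2.2-fold higher number from compound 1 to compound 3 (0.34 log units; beyond the scatter). Among these three compounds, the number in this assay therefore falls as the group at this place grows from hydrogen through 4-methoxyphenyl to 2-(4-methoxyphenyl)ethyl, and none of them goes against that order. Compound 3 still gives a measurable number with no aromatic ring at this place, so in this series the ring only shifts the read-out modestly and is not needed for a number to be obtained, but nothing shown here explains the shift.

The three compounds leave open whether the number would keep falling with a longer chain carrying the same 4-methoxyphenyl ring, or whether the trend would stop there. They also cannot separate the part played by the chain from that of the ring, which a plain butyl chain or an unsubstituted phenyl ring on the same chain would address.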